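The compounds below may be only part of what the source reports. "The series", "measured", "known", "first", "only" and "open" are said of these compounds alone.

Measured compounds:
compound 1, `COc1cc2c(cc1OC)C(c1ccccc1)=NNC(=O)C2`, 31.8 umol/kg
compound 2, `COc1cc2c(cc1OC)C(c1ccc(Cl)cc1)=NN=C(S)C2`, 55 umol/kg
compound 3, `COc1cc2c(cc1OC)C(c1ccc(Cl)cc1)=NNC(=O)C2`, 75.3 umol/kg

Compound 3 and compound 1 share one core and differ in one place, a change counted as hydrogen in place of chloro on an aromatic carbon. In a functional assay on the whole organism with Mus musculus as the target (a higher number here means that more compound is needed for the effect, a lower number that less compound is needed), this change gave a 2.4-fold lower number from compound 3 to compound 1 (0.37 log units; beyond the scatter). Compound 2 carries a different core; how the two cores differ is not broken down here. In this assay compound 2 gives 55 umol/kg, which sits within the scatter of both compound 3 and compound 1, so no order among the three can be read from these numbers.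

Compound 4, `COc1cc2c(cc1OC)C(c1ccccc1)=NN=C(S)C2`, has not been measured. It differs from compound 2 by hydrogen in place of chloro on an aromatic carbon, the same change that was made from compound 3 to compound 1. On the strength of that earlier step, the expected step is a 2.4-fold lower number from compound 2 to compound 4 (0.38 log units; beyond the scatter), because the same change from compound 3 to compound 1 produced a 2.4-fold lower number from compound 3 to compound 1 (0.37 log units; beyond the scatter). The estimate rests on a single measured pair, so the range is kept wide. Compound 4 is therefore expected to give about 23 umol/kg in this assay, within 12 umol/kg to 45 umol/kg.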

Compound 4, dose for half-maximal effect: 15 umol/kg
For compound 4 the middle estimate is 1.5-fold (0.19 log units) above the measured one, and the stated range covers the measured number.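

In this assay, going from 4-chlorophenyl to phenyl gave a 3.7-fold lower number from compound 2 to compound 4 (0.56 log units; beyond the scatter), so the change ran in the same direction on the second core as on the first. The two steps cannot be told apart in size: the same change on two cores in this assay, a 2.4-fold lower number (0.37 log units; beyond the scatter) from compound 3 to compound 1 and a 3.7-fold lower number (0.56 log units; beyond the scatter) from compound 2 to compound 4, 1.5-fold (0.19 log units) apart, within the scatter of two such steps. Among the compounds shown here, this is only two pairs on two cores in this assay, so it shows that the step carried over once, but it does not show that it would hold on any further core, and it gives no reason for the step.

The compounds shown leave open what other groups would do at this place on the ring, such as fluoro, methyl or an amine, as only chloro and hydrogen appear there. From the compounds shown here alone, the two methoxy groups also stay the same in all four compounds, so what a longer chain or a hydroxyl group would do in their place remains open.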